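Indazole-linked diaryl ureas: ring variation at the indazole

The source may report more compounds than this note shows. Statements on the series, on what has been measured and on what is new or still open speak of the compounds shown alone.

Measured so far in a functional assay on LoVo cells (Homo sapiens) for cytotoxicity, read by MTT assay, with a stated time of 72 h; on this read-out higher numbers stand for weaker inhibition and lower numbers for stronger inhibition:
compound 1 `O=C(Nc1ccc(-n2ncc3c(Br)cccc32)cc1)Nc1ccc(Cl)c(C(F)(F)F)c1` — 1700 nM
compound 2 `Cc1cccc2c1cnn2-c1ccc(NC(=O)Nc2ccc(Cl)c(C(F)(F)F)c2)cc1` — 3900 nM
compound 3 `O=C(Nc1ccc(-n2ncc3ccccc32)cc1)Nc1ccc(Cl)c(C(F)(F)F)c1` — 8700 nM

Compound 3 gives the highest number of the three. Its nearest neighbour is compound 2, with a 2.2-fold higher number from compound 2 to compound 3 (0.35 log units; beyond the scatter); the furthest is compound 1, with a 5.1-fold higher number from compound 1 to compound 3 (0.71 log units; beyond the scatter). The step between the two substituted analogues, a 2.3-fold higher number from compound 1 to compound 2 (0.36 log units; beyond the scatter), is of the same modest size. All three steps concern the group on an aromatic carbon of the shared core, and each lies beyond the scatter.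

Compound 4 `O=C(Nc1ccc(-n2ncc3ccncc32)cc1)Nc1ccc(Cl)c(C(F)(F)F)c1` differs from compound 3 in a different way: a group of 9 heavy atoms (6 carbon, 3 nitrogen; one five-membered aromatic ring with 2 hetero atoms, one six-membered aromatic ring with 1 hetero atom) in place of a group of 9 heavy atoms (7 carbon, 2 nitrogen; one five-membered aromatic ring with 2 hetero atoms, one six-membered aromatic ring of carbon only), on an aromatic carbon. The change sits on the aromatic carbon that is para to a large group, and it exchanges one bicyclic group for another of the same heavy-atom count, with one more nitrogen and one more hydrogen-bond acceptor.

For the measured compounds named here, none of the measured steps bears on this change; all three vary a substituent on the carbon-only six-membered ring rather than the ring itself. The expectation for this assay therefore rests only on compound 3 as the starting point, with wide uncertainty and no firm direction. The expected step is a 1.1-fold higher number from compound 3 to compound 4 (0.06 log units; within the scatter), which lies within the scatter. Compound 4 is estimated at 10000 nM, with a range from 3500 nM to 28000 nM.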

Compound 4, half-maximal inhibitory concentration: 7100 nM
Estimate against measurement, compound 4: 1.4-fold (0.15 log units) above; the range from low to high includes it.
By their numbers in this assay, from the lowest: compound 1; then compounds 2, 4 and 3 (each within the scatter of the next, the first and the last beyond it).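

In this assay, putting a nitrogen into the six-membered ring of the 1H-indazol-1-yl group, on an aromatic carbon para to a large group, gives a 1.2-fold lower number from compound 3 to compound 4 (0.09 log units; within the scatter), so this exchange of one bicyclic group for the other does not separate the two compounds. The comparison with the substituted analogues reads differently on each side: a 1.8-fold higher number from compound 2 to compound 4 (0.26 log units; within the scatter) leaves the methyl compound and the ring-nitrogen compound unresolved, although the methyl compound does stand apart from compound 3, while a 4.2-fold higher number from compound 1 to compound 4 (0.62 log units; beyond the scatter) keeps the bromo compound clear of compound 4, as it is clear of compound 3. Nothing available bears on why the ring change leaves the number within the scatter.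

Open, on these data alone, is whether a bromo or methyl group placed on the nitrogen-containing ring would repeat the steps these groups give on the carbon-only ring. Also open is how a chloro, methoxy or amine group would compare with bromo on the same carbon of the shared core, and whether the order of these compounds would hold in a second cell line.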